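Methyl to Propyl on the Piperazine Ring of a Cytotoxic Core

A few compounds are considered here, and "the series" means these few. Any claim that something is new, unique, unknown or untested is made for them only; others in the source may bear on it.

Compound 1 `CN1CCN(CCCCn2c3c(c4ccccc42)C(=O)c2c[n+]([O-])c4ccccc4c2C3=O)CC1` gives the lowest number of the two compounds measured in a functional assay on HCT-116 cells (Homo sapiens) for cytotoxicity, read by MTT assay, with a stated time of 72 h (a lower number here means a stronger inhibitor, a higher number a weaker inhibitor), with 10 nM; compound 2 `CC1(C)OC[C@H](Cn2cc(Cn3c4c(c5ccccc53)C(=O)c3c[n+]([O-])c5ccccc5c3C4=O)nn2)O1` gives 130 nM, a gap beyond the scatter. Compound 3 `CCCN1CCN(CCCCn2c3c(c4ccccc42)C(=O)c2c[n+]([O-])c4ccccc4c2C3=O)CC1` is not yet measured. It differs from compound 1 by ethyl in place of hydrogen on a saturated chain carbon bound to an amine nitrogen in a ring, so that the 4-methylpiperazin-1-yl group becomes 4-propylpiperazin-1-yl. For the measured compounds named here, no measured pair shows a change of this kind, so the expected step of a 1.2-fold higher number from compound 1 to compound 3 (0.08 log units; within the scatter) is small, within the scatter, with no clear direction. Compound 3 is therefore estimated at 12 nM, in a range from 4 nM to 40 nM.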

Compound 3, half-maximal inhibitory concentration: 790 nM
The estimate for compound 3 lay 66-fold (1.82 log units) below the measured number; the measured number lies above the stated range.
By their numbers in this assay, from the lowest: compound 1; then compound 2; then compound 3.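

In this assay, the change from 4-methylpiperazin-1-yl to 4-propylpiperazin-1-yl gives a 79-fold higher number from compound 1 to compound 3 (1.90 log units; beyond the scatter) and so shows that this end of the molecule is far from indifferent to its substituent: two added carbons are enough to weaken the compound sharply. Nothing measured here accounts for the rise. From the compounds shown here alone, it remains open whether the number climbs steadily with chain length, which a 4-ethylpiperazin-1-yl group could test. A plain hydrogen or a hydroxyethyl chain on that ring nitrogen might also behave like either methyl or propyl.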